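The source may report more compounds than this note shows. Statements on the series, on what has been measured and on what is new or still open speak of the compounds shown alone.

Measured compounds in an ADME assay on A549 cells (Homo sapiens) for cytotoxicity, read by CellTiter-Glo; a lower number here means that less compound is tolerated, a higher number that more compound is tolerated:
compound 1 `Cc1c(Cc2ccccc2)c(=O)oc2cc(OCC(O)CNc3ccccc3)ccc12`: > 100000 nM, a limit of the assay rather than a number.
compound 2 `Cc1c(Cc2ccccc2)c(=O)oc2cc(OCC(O)CNc3nccs3)ccc12`: 93000 nM.
compound 3 `Cc1c(Cc2ccc(C(C)(C)C)cc2)c(=O)oc2cc(OCC(O)CN3CCC(C(N)=O)CC3)ccc12`: 14700 nM.

Compound 3 gives the lowest of the two numbers in this assay; the nearest number, that of compound 2, lies higher by a margin beyond the scatter. Compound 1 sits at the limit of > 100000 nM in this assay, at which 1 of the 3 values shown sits. Within the data shown here, the one step measured, an at least 1.0-fold lower number from compound 1 to compound 2 (0.03 log units; that floor lies within the scatter), concerns the group on the amine nitrogen and its size stays within the scatter.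

Compound 4 `Cc1c(Cc2ccc(F)cc2F)c(=O)oc2cc(OCC(O)CN3CCC(C(N)=O)CC3)ccc12` differs from compound 3 by 2,4-difluorophenyl in place of 4-(tert-butyl)phenyl on a saturated chain carbon bound to an aromatic carbon. Among the measured compounds shown here, no measured step touches this position: compounds 1 and 2 both carry benzyl on the saturated chain carbon bound to an aromatic carbon while compound 3 carries 4-(tert-butyl)benzyl, but they also differ on the amine nitrogen, so the two changes cannot be separated. For the measured compounds named here, the only measured step, from compound 1 to compound 2, gives no guide to the present change. For compound 4 the step of a 2.0-fold higher number from compound 3 to compound 4 (0.31 log units; beyond the scatter) is expected to run toward a higher number, of a size that may stay within the scatter. Compound 4 is estimated at 30000 nM, between 10000 nM and 100000 nM.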

Compound 4, half-maximal cytotoxic concentration: > 100000 nM
Compound 4: a limit, no number; the forecaster's own chance of this, stated with the estimate: 20%; at least 3.3-fold (0.52 log units) between middle value and limit.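

In this assay, 2,4-difluorophenyl in place of 4-(tert-butyl)phenyl on a saturated chain carbon bound to an aromatic carbon gives an at least 6.8-fold higher number from compound 3 to compound 4 (0.83 log units; beyond the scatter). Among these compounds, this is the first reading of this position with the rest of the molecule held constant, since the earlier contrast between benzyl and 4-(tert-butyl)benzyl came with a different group on the amine nitrogen; the position therefore matters in this assay on its own, and the direction of this one change is clear. Compound 4 gives a limit of the assay rather than a number, so the step is a floor and its full size is unknown: the limit of > 100000 nM in this assay, at which 2 of the 4 values shown sit.

The compounds shown leave open whether the step goes with the loss of the tert-butyl group, the entry of the 2 fluorine atoms, or both, and a 4-fluorobenzyl or a 4-methylbenzyl on the same amine side would begin to separate these. Also open, as far as these compounds go, is how a 4-methoxybenzyl or a 4-chlorobenzyl would behave at this position, and whether 4-(tert-butyl)benzyl gives a similar step when paired with a different group on the amine nitrogen.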